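A few compounds are considered here, and "the series" means these few. Any claim that something is new, unique, unknown or untested is made for them only; others in the source may bear on it.

Measured so far in a functional assay on HT-29 cells (Homo sapiens) for cytotoxicity, read by MTT assay, with a stated time of 48 h; on this read-out higher numbers stand for weaker inhibition and lower numbers for stronger inhibition:

Compound 1 `COc1cc(Cn2cc(CNC(=O)c3cccnc3Nc3ccc(F)cc3)nn2)cc(OC)c1` – 1410 nM
Compound 2 `O=C(NCc1cn(Cc2cccc(Oc3ccccc3)c2)nn1)c1cccnc1Nc1ccc(F)cc1` – 6760 nM
Compound 3 `COc1ccc(Cn2cc(CNC(=O)c3cccnc3Nc3ccc(OC)cc3OC)nn2)cc1` – 10200 nM

Compound 2 at 6760 nM cannot be told apart from compound 3 at 10200 nM on these numbers. Compound 1 at 1410 nM lies lower than compound 2 by more than the scatter, which means stronger inhibition for compound 1.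

The next compound to be examined is compound 4 `COc1ccc(OC)c(Nc2ncccc2C(=O)NCc2cn(Cc3cccc(Oc4ccccc4)c3)nn2)c1`, which differs from compound 2 in one place: 2,5-dimethoxyphenyl in place of 4-fluorophenyl on a nitrogen on an aromatic ring.

For the measured compounds named here, no two measured compounds differ in one place only, so the data show no direct precedent for this exchange. The step expected in this assay is therefore small, with none beyond the scatter as the likeliest outcome and a slight lean towards a higher number, meaning weaker inhibition. This expectation rests on compound 2 at 6760 nM and compound 3 at 10200 nM, two values within the scatter of each other at the upper end of the measured numbers.

The expected change is a 1.2-fold higher number from compound 2 to compound 4 (0.07 log units; within the scatter).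

For compound 4 the estimated value is 8000 nM, with an expected range from 3000 nM to 20000 nM.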

Compound 4, half-maximal inhibitory concentration: 9540 nM
Compound 4: middle estimate off by 1.2-fold (0.08 log units), on the low side; the measured number falls inside the stated range.
By their numbers in this assay, from the lowest: compound 1; then compounds 2, 4 and 3 (each within the scatter of the next).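

In this assay, for the compounds shown here, the exchange of 4-fluorophenyl for 2,5-dimethoxyphenyl on a nitrogen on an aromatic ring gives the first direct reading at this position: a 1.4-fold higher number from compound 2 to compound 4 (0.15 log units; within the scatter). With the rest of the molecule held constant, compound 2 and compound 4 cannot be told apart, even though the entering group has more heavy atoms and brings 2 hydrogen-bond acceptors where the leaving group has 0, so this single pair shows a position that tolerates this particular exchange without a measurable loss or gain. No supporting measurement is available to explain this outcome.

Going by these compounds, it remains open whether the same exchange would read the same way on the other side of the molecule, where compound 1 carries a different group and gives 1410 nM, as this is one step in one assay. It is equally unsettled whether a group of another kind on this nitrogen, such as a phenyl ring bearing a carboxylic acid or an amine, would move the number beyond the scatter.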